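The compounds below may be only part of what the source reports. "The series", "measured", "known", "first", "only" and "open" are said of these compounds alone.

Measured in a functional assay on THP-1 cells (Homo sapiens) for inhibition, read by ELISA, with stated times of 2 h and 48 h; on this read-out higher numbers stand for weaker inhibition and lower numbers for stronger inhibition:
- compound 1 `COc1ccc(-n2cc(/C=[N+](\[O-])Cc3ccccc3)nn2)cc1`: 17300 nM
- compound 2 `CC(C)(C)/[N+]([O-])=C/c1cn(-c2ccccc2)nn1`: > 20000 nM (a limit of the assay, not a number)
- compound 3 `CC(C)(C)/[N+]([O-])=C/c1cn(-c2ccc(F)cc2)nn1`: 14000 nM

Only compound 1 and compound 3 have true numbers here, and those two numbers lie within the usual scatter of each other. The still unmeasured compound 4 `COc1ccc(-n2cc(/C=[N+](\[O-])C(C)(C)C)nn2)cc1` differs from compound 3 in a single place: methoxy in place of fluoro on an aromatic carbon. This is methoxy in place of fluoro on an aromatic carbon, para to a large group.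

Among the measured compounds shown here, one measured step concerns a change on an aromatic carbon, fluoro in place of hydrogen: an at least 1.4-fold lower number from compound 2 to compound 3 (0.15 log units; that floor lies within the scatter). That step starts from a limit, so only its smallest possible size is known, and this gives no firm sign of a large effect from such a swap. Compound 1 also carries methoxy and gives 17300 nM, which is within the scatter of compound 3.

No step beyond the scatter is therefore expected in this assay, and the estimated change is a 1.1-fold higher number from compound 3 to compound 4 (0.03 log units; within the scatter). For compound 4 the expected value is 15000 nM, with an estimated range from 7000 nM to 30000 nM.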

Compound 4, half-maximal inhibitory concentration: 13500 nM
Estimate against measurement, compound 4: 1.1-fold (0.05 log units) above; low and high end bracket the measured number.
By their numbers in this assay, from the lowest: compounds 4, 3 and 1 (each within the scatter of the next). At a limit, above all of these: compound 2.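

In this assay, putting methoxy in place of fluoro on this aromatic carbon, para to a large group, gives a 1.0-fold lower number from compound 3 to compound 4 (0.02 log units; within the scatter), so the two groups cannot be told apart here. Among the compounds shown here, compound 4 also forms the first matched pair for the group on the double-bonded nitrogen, and tert-butyl in place of benzyl, with methoxy held fixed, gives a 1.3-fold lower number from compound 1 to compound 4 (0.11 log units; within the scatter), so that change cannot be told from scatter either. Methoxy in place of hydrogen gives an at least 1.4-fold lower number from compound 2 to compound 4 (0.17 log units; that floor lies within the scatter), but because compound 2 stands at a limit of the assay and not at a true number, this floor cannot show how far either methoxy or fluoro differs from hydrogen: the limit of > 20000 nM in this assay, at which 1 of the 4 values shown sits.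

The compounds shown leave open whether an amine, a carboxylic acid or a longer chain such as butoxy on this aromatic carbon would move the number beyond the scatter. From the compounds shown here alone, all the true numbers here lie within the scatter of their neighbours, so it also stays open which part of the shared core, if any, can shift inhibition in a clear way.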